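The source may report more compounds than this note shows. Statements on the series, on what has been measured and on what is new or still open speak of the compounds shown alone.

Measured compounds in the series:

compound 1 `C=CCn1c(=O)/c(=C\c2ccc(Cl)c(Cl)c2)[nH]c(=O)/c1=C\c1ccccc1OC` — "not active" (no number reported) in a functional assay on BGC-823 cells (Homo sapiens) for cytotoxicity, read by CCK-8 assay, with a stated time of 72 h; a higher number here means a weaker inhibitor, a lower number a stronger inhibitor
compound 2 `C=CCn1c(=O)/c(=C\c2cc(Br)ccc2F)[nH]c(=O)/c1=C\c1ccccc1OC` — "not active" (no number reported) in this assay
compound 3 `C=CCn1c(=O)/c(=C\c2cccc(Br)c2)[nH]c(=O)/c1=C\c1ccccc1OC` — 5900 nM in this assay

Among the measured compounds shown here, compound 3 stands as the only member of the three with a number reported; compound 1 and compound 2 carry no number and are recorded only as inactive. Compound 3 therefore sets the one fixed point against which the next analogue is judged. For the measured compounds named here, no pair among the measured compounds differs in a single place, so no measured step is available.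

Compound 4 `C=CCn1c(=O)/c(=C\c2cccc(C)c2)[nH]c(=O)/c1=C\c1ccccc1OC` differs from compound 3 by one change: methyl in place of bromo on an aromatic carbon. The bromo is replaced by methyl on the aromatic carbon of the six-membered carbon ring, meta to a large group, so the 3-bromophenyl becomes 3-methylphenyl.

Going by the values given here, with no measured step to draw on, the expectation for this assay is a change that may well fall within the scatter, with some chance of a modest move towards a weaker inhibitor; the estimated step is a 1.4-fold higher number from compound 3 to compound 4 (0.13 log units; within the scatter). Compound 4 is expected to give 8000 nM, with a likely range from 3000 nM to 25000 nM. It is possible that compound 4, like compound 1 and compound 2, returns no number at all.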

Compound 4, half-maximal inhibitory concentration: 20400 nM
Compound 4: middle estimate off by 2.6-fold (0.41 log units), on the low side, and the stated range covers the measured number.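

In this assay, among the compounds shown here, the exchange of bromo for methyl on an aromatic carbon, meta to a large group, gives a 3.5-fold higher number from compound 3 to compound 4 (0.54 log units; beyond the scatter) and is the first measured step; it shows that this position responds to the choice of substituent, with the 3-bromophenyl compound giving the lower number of the pair. This response appears even though the two groups match in heavy-atom count and neither carries a hydrogen-bond donor, a hydrogen-bond acceptor or a net charge, so those counts alone do not settle the reading at this place. No measurement at hand speaks to what lies behind the difference between bromo and methyl.

As far as these compounds go, with only these two groups seen at this place, it remains open whether chloro, methoxy, hydroxyl, an amine or a carboxylic acid would read nearer compound 3 or compound 4, and whether a longer chain such as ethyl or propyl would extend the rise seen with methyl. Also open, from the compounds shown here alone, is whether the same exchange gives a step of similar size at other carbons of the ring, or alongside a second substituent as in compound 1 and compound 2.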